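Shortening the alkyl chain on a weak pyrimidinedione-type inhibitor

A few compounds are considered here, and "the series" means these few. Any claim that something is new, unique, unknown or untested is made for them only; others in the source may bear on it.

Measured compounds:
- compound 1, `CCCCCc1ccc(C#Cc2cn(C/C=C\CN3C(=O)c4ccccc4C3=O)c(=O)[nH]c2=O)cc1`: 30000 nM
- compound 2, `CCCCCc1ccc(C#Cc2cn(C/C=C/CN3C(=O)c4ccccc4C3=O)c(=O)[nH]c2=O)cc1`: 17000 nM

Both compounds were tested in a functional assay on MOLT-4 cells (Homo sapiens) for antiproliferative activity, read by MTT assay, with a stated time of 3 days; a higher number here means a weaker inhibitor, a lower number a stronger inhibitor. Compound 1 gives 30000 nM, and with two numbers available compound 1 holds the higher one. The two compounds have the same atoms and bonds and differ only in how one double bond is drawn, which is why the step of a 1.8-fold lower number from compound 1 to compound 2 (0.25 log units; within the scatter) says little about chain changes (the fact that compounds 1 and 2 differ only in the configuration as drawn).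

Compound 3, `CCCCc1ccc(C#Cc2cn(C/C=C\CN3C(=O)c4ccccc4C3=O)c(=O)[nH]c2=O)cc1`, has not yet been measured. It differs from compound 1 by hydrogen in place of methyl on a saturated chain carbon, four bonds along the chain from an aromatic carbon, that is, the side chain on the aromatic ring becomes one carbon shorter. Among the compounds with values here, no measured step touches this part of the molecule; the only measured step, a 1.8-fold lower number from compound 1 to compound 2 (0.25 log units; within the scatter), concerns a different place and lies within the scatter. With nothing pointing up or down, no step beyond the scatter is expected here, and the estimated step is no change at the digits printed from compound 1 to compound 3 (within the scatter). Compound 3 is therefore expected to give about 30000 nM, in a range from 12000 nM to 80000 nM.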

Compound 3, half-maximal inhibitory concentration: 31000 nM
For compound 3 the middle estimate is 1.0-fold (0.01 log units) below the measured one; the measured number falls inside the stated range.
By their numbers in this assay, from the lowest: compounds 2, 1 and 3 (each within the scatter of the next).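

In this assay, the side chain on the aromatic ring can lose its end carbon with no change that stands out from the scatter (a 1.0-fold higher number from compound 1 to compound 3 (0.01 log units; within the scatter)). Within the data shown here, this is the first measured change at this end of the molecule, and unlike the earlier double-bond comparison, it tests the chain itself: replacing methyl with hydrogen at this place neither helps nor harms measurably, so compound 3 and compound 1 cannot be told apart here. That single result covers only one carbon, so it does not show that the whole chain is unimportant, and nothing in the data on hand explains why this change leaves the number in place.

Still open, going by these compounds, is whether cutting the chain back much further, or replacing it with a longer chain, would move the number beyond the scatter, and whether an amine or a carboxylic acid at the chain end would do so. Also open, on these data alone, is whether the same one-carbon change would behave alike on compound 2, whose double bond is drawn the other way.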